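The source may report more compounds than this note shows. Statements on the series, on what has been measured and on what is new or still open speak of the compounds shown alone.

Measured compounds in a functional assay on M14 cells (Homo sapiens) for antiproliferative activity, with a stated time of 72 h; on this read-out lower numbers stand for stronger inhibition and higher numbers for weaker inhibition:
- Compound 1, `C=CC[C@H]1C[C@]2([C@@H](C)Cc3ccc(OC)c(OC)c3)OCOC2=CC1=O`: 110 nM
- Compound 2, `C=CC[C@H]1C[C@]2([C@@H](C)Cc3ccc(OC)c(C(=O)NC)c3)OCOC2=CC1=O`: 1400 nM
- Compound 3, `C=CC[C@H]1C[C@]2([C@@H](C)Cc3ccc(OC)c(NC(C)=O)c3)OCOC2=CC1=O`: 85 nM

Compound 3 sits at the low end of the three numbers. Its nearest neighbour is separated by a 1.3-fold lower number from compound 1 to compound 3 (0.11 log units; within the scatter), which lies within the scatter; the furthest is separated by a 16-fold lower number from compound 2 to compound 3 (1.22 log units; beyond the scatter), a large step. The third step, a 13-fold higher number from compound 1 to compound 2 (1.10 log units; beyond the scatter), is likewise large.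

Compound 4, `C=CC[C@H]1C[C@]2([C@@H](C)Cc3ccc(OC)c(Cl)c3)OCOC2=CC1=O`, is not yet measured. It differs from compound 3 by chloro in place of acetamido on an aromatic carbon. Within the data shown here, no measured step involves a chloro group, so the bearing of the earlier steps is indirect. The methoxy and acetamido analogues, compound 1 and compound 3, lie within the scatter of each other, whereas the methylcarbamoyl analogue, compound 2, falls far off. A small substituent without donor or acceptor is therefore expected to land near compound 1 and compound 3 rather than near compound 2, with a step of no more than modest size and wide uncertainty. The expected step from compound 3 is a 1.8-fold higher number from compound 3 to compound 4 (0.25 log units; within the scatter). For compound 4 the estimate in this assay is 150 nM, range 50 nM to 500 nM.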

Compound 4, half-maximal inhibitory concentration: 240 nM
Beside the measured number, compound 4's estimate is 1.6-fold (0.20 log units) below it, within the range that was stated.
By their numbers in this assay, from the lowest: compounds 3 and 1 (each within the scatter of the next); then compound 4; then compound 2.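

In this assay this position, ortho to a methoxy group, proves not to be indifferent to small replacements: chloro separates modestly from both acetamido (a 2.8-fold higher number from compound 3 to compound 4 (0.45 log units; beyond the scatter)) and methoxy (a 2.2-fold higher number from compound 1 to compound 4 (0.34 log units; beyond the scatter)), which compounds 1 and 3 alone could not show. Chloro, with 0 hydrogen-bond donors and 0 hydrogen-bond acceptors, still stays well clear of the methylcarbamoyl analogue (a 5.8-fold lower number from compound 2 to compound 4 (0.77 log units; beyond the scatter)), so the large penalty seen with compound 2 is not shared by every departure from methoxy or acetamido. No evidence on the cause of these steps is at hand.

As far as these compounds go, whether the modest step belongs to chloro itself or would recur with fluoro, methyl or a primary amine at this position remains open. Also open, from the compounds shown here alone, is whether a longer acyl chain on the acetamido nitrogen would hold the level of compound 3.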